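The source may hold more compounds than are shown below. What is called first, only, known or untested is meant among the compounds shown, and "the series" means these compounds.

Going by the values given here, compound 1, with the structure `CCn1ncnc1-c1ccccc1NCC1=NCCN1`, is one of two compounds measured so far in a functional assay with Alpha-1A adrenergic receptor (Homo sapiens) as the target, read by calcium flux; on this read-out higher numbers stand for larger maximal responses and lower numbers for smaller maximal responses. In this assay compound 1 gives 107%, the highest of the two numbers. The second compound, compound 2, with the structure `Cc1ccc(-c2ccccc2NCC2=NCCN2)n1C`, gives in this assay 78%, a number that lies well below that of compound 1, by more than the usual scatter. Compound 2 differs from compound 1 in more than one place, so nothing more can be read from that pair than what the two numbers show.

The next compound, compound 3, with the structure `Cn1ncnc1-c1ccccc1NCC1=NCCN1`, has not yet been measured in this assay. It differs from compound 1 in a single respect: hydrogen in place of methyl on a saturated chain carbon bound to an aromatic nitrogen. Among the compounds with values here, no pair of measured compounds that differs only in this way is available, so there is no measured step to lean on. Given that compound 1 gives 107% in this assay and that the change is small, the step from compound 1 to compound 3 is expected to be a number 7 percentage points lower from compound 1 to compound 3 (within the scatter), in either direction and not beyond the scatter. Compound 3 is therefore estimated to give 100% in this assay, with a range from 85% to 115%.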

Compound 3, largest response reached (reported as maximal response), in percent of the reference or control that the assay uses: 91%
Beside the measured number, compound 3's estimate is 9 percentage points above it; the measured number falls inside the stated range.
By their numbers in this assay, from the lowest: compound 2; then compound 3; then compound 1.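

In this assay, hydrogen in place of methyl on a saturated chain carbon bound to an aromatic nitrogen, the same change as ethyl to methyl, gives a number 16 percentage points lower from compound 1 to compound 3 (beyond the scatter). Going by these compounds alone, this is the first reading of a change at this place, and it shows that the place is not silent: the loss of one carbon, with no ring, no hydrogen-bond donor or acceptor and no net charge leaving or entering, moves the maximal response beyond the usual scatter. Of this single pair, the ethyl compound gives the larger response, but one step sets no trend along the chain. Nothing at hand accounts for the size of this step.

The compounds shown leave open how the maximal response in this assay runs on with a longer chain at this place, such as propyl or butyl, and whether a branched group such as isopropyl or an ether chain such as methoxyethyl would stay with compound 1 or fall away from it. They also leave open what a cyclopropyl group would give there.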